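The source may report more compounds than this note shows. Statements on the series, on what has been measured and on what is new or still open speak of the compounds shown alone.

Three compounds of the series have numbers in an assay on HEK293 cells for displacement of a labelled ligand from NPC1-like intracellular cholesterol transporter 1 (Homo sapiens); on this read-out higher numbers stand for weaker inhibition and lower numbers for stronger inhibition. Compound 1 `CC(C)(C)c1ccc(C(=O)N2CCC3(CC2)C(=O)N(CC(=O)N2CCNCC2)CN3c2ccccc2)cc1` gives 22000 nM, compound 2 `CCC1CCCN(C(=O)CN2CN(c3ccccc3)C3(CCN(C(=O)c4ccc(C(C)(C)C)cc4)CC3)C2=O)C1` gives 3900 nM, and compound 3 `CC(C)(C)c1ccc(C(=O)N2CCC3(CC2)C(=O)N(CC(=O)NCCCN)CN3c2ccccc2)cc1` gives 4200 nM. Compound 3 thus stands second highest of the three, within the scatter of compound 2 and well apart from compound 1. Compound 4 `CC(C)(C)c1ccc(C(=O)N2CCC3(CC2)C(=O)N(CC(=O)N2CCC(CCO)CC2)CN3c2ccccc2)cc1` is not yet measured; it differs from compound 3 as follows: 4-(2-hydroxyethyl)piperidin-1-yl in place of (3-aminopropyl)amino on a carbonyl carbon. For the measured compounds named here, the steps that bear on this are a 5.6-fold lower number from compound 1 to compound 2 (0.75 log units; beyond the scatter), a 5.2-fold lower number from compound 1 to compound 3 (0.72 log units; beyond the scatter) and a 1.1-fold higher number from compound 2 to compound 3 (0.03 log units; within the scatter); the two replacements of piperazin-1-yl moved the number by similar amounts, while the exchange of 3-ethylpiperidin-1-yl for (3-aminopropyl)amino stayed within the scatter. For compound 4 the expected step in this assay is therefore estimated as a 1.1-fold lower number from compound 3 to compound 4 (0.02 log units; within the scatter). The estimate for compound 4 is 4000 nM, with a range from 1500 nM to 11000 nM.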

Compound 4, half-maximal inhibitory concentration: 2600 nM
Compound 4: the middle estimate sits 1.5-fold (0.19 log units) above what was measured; the measured number falls inside the stated range.
By their numbers in this assay, from the lowest: compounds 4, 2 and 3 (each within the scatter of the next); then compound 1.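

In this assay the carbonyl carbon accepts 4-(2-hydroxyethyl)piperidin-1-yl at the level of the two earlier replacements of piperazin-1-yl: a 1.6-fold lower number from compound 3 to compound 4 (0.21 log units; within the scatter) and a 1.5-fold lower number from compound 2 to compound 4 (0.18 log units; within the scatter) both lie within the scatter. Against piperazin-1-yl there is an 8.5-fold lower number from compound 1 to compound 4 (0.93 log units; beyond the scatter) and compound 1 alone stands apart from the other three. No measurement at hand accounts for that gap.

Still open, from the compounds shown here alone, is whether a carboxylic acid or unsubstituted piperidin-1-yl on this carbonyl carbon stays at the same level. Also open, going by these compounds, is whether any group here moves the number beyond the scatter of compound 2, compound 3 and compound 4.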